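From compound 2 to compound 3: one added chloro

This account rests on a few compounds, and the source may have more. Where it says the series, first, only, none or still open, it means among the compounds named here.

- Compound 1 `COC(=O)c1ccc(NC(=O)CSc2nc3ccc(Cl)cc3n2S(=O)(=O)c2cc(C)cc(C)c2)c(Cl)c1`: >= 130000 nM
- Compound 2 `Cc1cc(C)cc(S(=O)(=O)n2c(SCC(=O)Nc3ccc(S(C)(=O)=O)cc3Cl)nc3ccccc32)c1`: > 221000 nM

In an ADME assay on MT4 cells (Homo sapiens) for cytotoxicity (on this read-out lower numbers stand for higher toxicity in this test and higher numbers for lower toxicity in this test), compound 2 gives > 221000 nM, which is a limit and not a number. Compound 1 gives >= 130000 nM, and this too is a limit. With no exact number for either compound, the two cannot be ranked against each other.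

Compound 3 `Cc1cc(C)cc(S(=O)(=O)n2c(SCC(=O)Nc3ccc(S(C)(=O)=O)cc3Cl)nc3ccc(Cl)cc32)c1` differs from compound 2 in one place: chloro in place of hydrogen on an aromatic carbon. The change is chloro in place of hydrogen on an aromatic carbon, on a six-membered aromatic ring of carbon only that is part of a fused or bridged system of two rings.

Among the compounds with values here, no measured pair shows this change on its own. The core of compound 1 also carries a chloro, although compound 1 differs elsewhere, and its limit is >= 130000 nM. On that basis, I expect no step beyond the usual scatter, and compound 3 may well return only a limit. The expected change is an at least 1.3-fold lower number from compound 2 to compound 3 (0.11 log units; that floor lies within the scatter).

In this assay the estimate for compound 3 is 170000 nM, with an expected range from 70000 nM to 320000 nM.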

Compound 3, half-maximal cytotoxic concentration: 3590 nM
Estimate against measurement, compound 3: 47-fold (1.68 log units) above; measured number outside the range, below it.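

In this assay, one added chloro on the six-membered aromatic ring of the shared core is enough to bring a measured number into a set that had shown only limits: an at least 61-fold lower number from compound 2 to compound 3 (1.78 log units; beyond the scatter). This chloro does not act alone, since compound 1 already carries it on its core, and methylsulfonyl in place of methoxycarbonyl on an aromatic carbon gives an at least 36-fold lower number from compound 1 to compound 3 (1.55 log units; beyond the scatter). Among these compounds, the low number appears only in compound 3, where chloro and methylsulfonyl occur together, while compound 1 has only the chloro and compound 2 only the methylsulfonyl, and the true size of the chloro step stays open because it starts from a limit: the limit of > 221000 nM in this assay, at which 1 of the 3 values shown sits.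

The compounds shown leave open whether this drop belongs to chloro specifically, which a fluoro, a methyl or an amine on the same aromatic carbon could help to settle. They also leave open whether methylsulfonyl itself is needed for the drop, or whether another group in its place, such as a carboxylic acid, would give a similarly low number alongside the chloro.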